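The source may report more compounds than this note shows. Statements on the series, on what has been measured and on what is new or still open speak of the compounds shown alone.

Measured in an assay on microsomes for inhibition of acyl-CoA:cholesterol acyltransferase (Oryctolagus cuniculus); on this read-out lower numbers stand for stronger inhibition and higher numbers for weaker inhibition:
- compound 1, `CC(C)c1cccc(C(C)C)c1NC(=O)NCC1(c2ccc(CC(C)(C)C)cc2)CCCC1`: 159 nM
- compound 2, `CC(C)c1cccc(C(C)C)c1NC(=O)NCC1(c2ccc(C(F)(F)F)cc2)CCCC1`: 66 nM
- compound 3, `CC(C)c1cccc(C(C)C)c1NC(=O)NCC1(c2ccc([N+](=O)[O-])cc2)CCCC1`: 131 nM

Compound 1 gives the highest number of the three, but its gap to compound 3 lies within the scatter; only compound 2 is clearly separated from it. Compound 4, `CC(C)c1cccc(C(C)C)c1NC(=O)NCC1(c2ccc(N)cc2)CCCC1`, has not been measured; from compound 1 the change is amino in place of neopentyl on an aromatic carbon. Two measured steps replace the same neopentyl at the same place: a 2.4-fold lower number from compound 1 to compound 2 (0.38 log units; beyond the scatter) and a 1.2-fold lower number from compound 1 to compound 3 (0.08 log units; within the scatter). Between the two replacing groups there is a 2.0-fold higher number from compound 2 to compound 3 (0.30 log units; within the scatter). Neither step introduces an amino group, so the measured steps bear on compound 4 only in showing that exchanging the neopentyl at this place has so far moved the number little, with one modest lowering at most. For compound 4 the expected step is therefore a 1.1-fold lower number from compound 1 to compound 4 (0.03 log units; within the scatter), small and not confidently beyond the scatter. The estimate for compound 4 in this assay is 150 nM, within 50 nM to 500 nM.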

Compound 4, half-maximal inhibitory concentration: 29 nM
The estimate for compound 4 lay 5.2-fold (0.71 log units) above the measured number; the measured number lies below the stated range.
By their numbers in this assay, from the lowest: compound 4; then compounds 2, 3 and 1 (each within the scatter of the next, the first and the last beyond it).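

In this assay, within the data shown here, the aromatic carbon para to a large group proves more sensitive than compounds 1, 2 and 3 suggested: amino gives a 5.5-fold lower number from compound 1 to compound 4 (0.74 log units; beyond the scatter) and is the first replacement of neopentyl here to produce a step of this size. The amino group also separates from both earlier replacing groups, with a 4.5-fold lower number from compound 3 to compound 4 (0.65 log units; beyond the scatter) and a 2.3-fold lower number from compound 2 to compound 4 (0.36 log units; beyond the scatter) as the two steps, so compound 4 has the lowest number of the four and the identity of the group at this place clearly matters. Nothing available here accounts for these differences.

As far as these compounds go, whether the lowering is specific to the free amino group remains open, and a methylamino, dimethylamino, acetamido or hydroxyl group at the same place would bear on that. From the compounds shown here alone, it is also open whether the amino step would carry over to a core other than that of compound 1.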